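Trimming the amide methyl in a melatonin-like series

A few compounds are considered here, and "the series" means these few. Any claim that something is new, unique, unknown or untested is made for them only; others in the source may bear on it.

Measured so far:
compound 1, `CC(=O)NCCC1=COc2ccccc2O1`: 1000 nM
compound 2, `COc1ccc2cccc(CCCC(N)=O)c2c1`: 20 nM
compound 3, `CNC(=O)CCc1cccc2ccc(OC)cc12`: 12.6 nM

In an assay (Ovis aries) for binding affinity to melatonin receptor type 1A (Homo sapiens) (a lower number here means a stronger inhibitor, a higher number a weaker inhibitor), compound 3 gives the lowest of the three numbers. Its nearest neighbour is compound 2, and the step of a 1.6-fold lower number from compound 2 to compound 3 (0.20 log units; within the scatter) lies within the scatter, so the two cannot be ranked against each other. Compound 1, built on a different core, stands far higher.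

Compound 4, `COc1ccc2cccc(CCC(N)=O)c2c1`, keeps the core and the chain of compound 3 and changes only the amide end: hydrogen in place of methyl on an amide-type nitrogen. Within the data shown here, none of the measured steps makes this single change on its own. The step from compound 2 to compound 3 moves the amide nitrogen from unsubstituted to methyl-bearing, but it also alters the chain length at the same time, so it bears on the question only loosely; its size was small. With no closer guide, a modest rise in the number is expected for compound 4, giving an estimated step of a 2.0-fold higher number from compound 3 to compound 4 (0.30 log units; within the scatter). Compound 4 is therefore expected to give about 25 nM, within a range of 8 nM to 80 nM.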

Compound 4, half-maximal inhibitory concentration: 1000 nM
Compound 4: middle estimate off by 40-fold (1.60 log units), on the low side, and the stated range ends below it.
By their numbers in this assay, from the lowest: compounds 3 and 2 (each within the scatter of the next); then compounds 1 and 4 (each within the scatter of the next).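

In this assay the methyl on the amide-type nitrogen proves far from a minor detail: hydrogen in place of methyl gives a 79-fold higher number from compound 3 to compound 4 (1.90 log units; beyond the scatter), a step well beyond the scatter. The unsubstituted amide does not always give a high number, though: carbamoyl in place of carbamoylmethyl on the chain gives a 50-fold higher number from compound 2 to compound 4 (1.70 log units; beyond the scatter), so the same amide end sits at a low number on the longer chain and a high one on the shorter chain. Among these compounds, compound 3 with its methyl and compound 2 with its extra chain carbon stay within the scatter of each other, while compound 4, with neither, stands far higher.

As far as these compounds go, whether an ethyl group on the same nitrogen, or a methyl amide on a longer chain, would keep the number low remains open. No measurement at hand bears on why this step is so large.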